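The source may hold more compounds than are shown below. What is called first, only, known or untested is meant among the compounds shown, and "the series" means these compounds.

In a functional assay on A549 cells (Homo sapiens) for inhibition, read by CCK-8 assay, with a stated time of 72 h, tested at 8 uM (on this read-out lower numbers stand for less inhibition of growth and higher numbers for more inhibition of growth at the one concentration tested), compound 1 `Cc1ccc(SCc2ccc(/C=C/C(=O)Nc3ccccc3N)cc2)cc1` gives 48.3%, while compound 2 `Cc1ccc(SCc2ccc(C(=O)Nc3ccccc3N)cc2)cc1` gives 78.3%. Compound 2 therefore holds the higher of the two numbers, and the gap between them lies beyond the usual scatter. Compound 3 `Nc1ccccc1NC(=O)c1ccc(CSc2ccc(Cl)cc2)cc1` differs from compound 2 in one place: chloro in place of methyl on an aromatic carbon. For the measured compounds named here, no measured pair yet shows the effect of this swap, so no step beyond the scatter is expected in this assay. The estimated change is a number 3.3 percentage points lower from compound 2 to compound 3 (within the scatter). The expected value for compound 3 is 75%, within a range of 58% to 90%.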

Compound 3, percent growth inhibition at one concentration: 50.4%
Estimate against measurement, compound 3: 24.6 percentage points above, outside the stated range (below it).
By their numbers in this assay, from the lowest: compounds 1 and 3 (each within the scatter of the next); then compound 2.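

In this assay, putting chloro in place of methyl on the aromatic carbon para to a large group gives a number 27.9 percentage points lower from compound 2 to compound 3 (beyond the scatter) as the first measured result for this swap. It shows that this position is sensitive: exchanging one heavy atom, with no change in the count of rings, hydrogen-bond donors or acceptors, moves the growth inhibition beyond the scatter. Nothing shown here accounts for the size of this step. As far as these compounds go, whether a methoxy group, a fluoro group or an amine at this position would read closer to compound 2 or to compound 3 stays open. So does whether the same swap would act alike on the core of compound 1.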